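Moving a Methoxy Group on the Styryl Diol Series

The source may hold more compounds than are shown below. What is called first, only, known or untested is meant among the compounds shown, and "the series" means these compounds.

- compound 1 `CC1(C)CCC[C@]2(C)[C@@H](CC[C@@](C)(O)/C=C/c3cccc([N+](=O)[O-])c3)[C@](C)(O)CC[C@@H]12`: 3380 nM
- compound 2 `Cc1ccc(C)c(/C=C/[C@](C)(O)CC[C@@H]2[C@@]3(C)CCCC(C)(C)[C@@H]3CC[C@@]2(C)O)c1`: 3380 nM
- compound 3 `COc1cccc(OC)c1/C=C/[C@](C)(O)CC[C@@H]1[C@@]2(C)CCCC(C)(C)[C@@H]2CC[C@@]1(C)O`: 48200 nM

In a functional assay on HeLa cells (Homo sapiens) for cytotoxicity, read by MTT assay, with a stated time of 48 h (on this read-out higher numbers stand for weaker inhibition and lower numbers for stronger inhibition), compound 3 stands highest of the three at 48200 nM. Compound 4 `COc1cccc(/C=C/[C@](C)(O)CC[C@@H]2[C@@]3(C)CCCC(C)(C)[C@@H]3CC[C@@]2(C)O)c1OC` carries 2,3-dimethoxyphenyl in place of 2,6-dimethoxyphenyl on a double-bonded chain carbon bound to a double-bonded chain carbon. Two large measured steps bear on this change, a 14-fold higher number from compound 1 to compound 3 (1.15 log units; beyond the scatter) and a 14-fold higher number from compound 2 to compound 3 (1.15 log units; beyond the scatter), whereas no change at the digits printed from compound 1 to compound 2 (within the scatter) stays within the scatter. Among the compounds with values here, no measured compound carries 2,3-dimethoxyphenyl, so the guide is indirect. Going by a 14-fold higher number from compound 2 to compound 3 (1.15 log units; beyond the scatter), a move to a lower number in this assay is expected, though probably a smaller one. The expected step is a 5.4-fold lower number from compound 3 to compound 4 (0.73 log units; beyond the scatter). For compound 4 the estimated value is 9000 nM, with an expected range of 2500 nM to 40000 nM.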

Compound 4, half-maximal inhibitory concentration: 3880 nM
Estimate against measurement, compound 4: 2.3-fold (0.37 log units) above; low and high end bracket the measured number.
By their numbers in this assay, from the lowest: compounds 1, 2 and 4 (each within the scatter of the next); then compound 3.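

Replacing 2,6-dimethoxyphenyl with 2,3-dimethoxyphenyl keeps the same atoms but gives a 12-fold lower number from compound 3 to compound 4 (1.09 log units; beyond the scatter) in this assay, so the placing of the two methoxy groups matters at this position, not only their presence. The other two steps, a 1.1-fold higher number from compound 2 to compound 4 (0.06 log units; within the scatter) and a 1.1-fold higher number from compound 1 to compound 4 (0.06 log units; within the scatter), leave no separation among those three compounds, and of the four aryl groups only 2,6-dimethoxyphenyl stands apart. Nothing available here explains this difference.

Going by these compounds, whether a single methoxy group, an amine or a hydroxyl group on this ring would match compound 4 or compound 3 stays open.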